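Shortened linker and a chlorinated sulfonamide in compound 4

The source may report more compounds than this note shows. Statements on the series, on what has been measured and on what is new or still open speak of the compounds shown alone.

Compound 1 `O=S(=O)(NCCCNc1nccc(-c2c(-c3cccc(F)c3)nc3sccn23)n1)c1ccc(F)cc1`: 14500 nM
Compound 2 `O=C(NCCNc1nccc(-c2c(-c3cccc(F)c3)nc3sccn23)n1)c1c(F)cccc1F`: 2700 nM
Compound 3 `O=S(=O)(NCCCNc1nccc(-c2c(-c3cccc(F)c3)nc3sccn23)n1)c1ccc(C(F)(F)F)cc1`: 4090 nM

Of the compounds shown here, three sharing one core have been measured in a functional assay on A-375 cells (Homo sapiens) for cytotoxicity, read by MTT assay; on this read-out lower numbers stand for stronger inhibition and higher numbers for weaker inhibition. Compound 1 gives the highest of the three numbers; compound 3 lies nearest to it, and compound 2 furthest away. Compound 4 `O=S(=O)(NCCNc1nccc(-c2c(-c3cccc(F)c3)nc3sccn23)n1)c1ccc(Cl)cc1` is the next compound to be measured. It differs from compound 1 in one place: ((4-chlorophenyl)sulfonyl)amino in place of (((4-fluorophenyl)sulfonyl)amino)methyl on a saturated chain carbon, two bonds along the chain from a nitrogen on an aromatic ring.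

Among the compounds with values here, two measured steps bear on this change. From compound 1 to compound 2, the chain was shortened at the same position and the sulfonamide exchanged for an amide, giving a 5.4-fold lower number from compound 1 to compound 2 (0.73 log units; beyond the scatter). From compound 1 to compound 3, only the group on the aromatic ring was exchanged, giving a 3.5-fold lower number from compound 1 to compound 3 (0.55 log units; beyond the scatter). Both steps moved the number downward, so a downward move is expected here as well, though neither step reproduces the change exactly.

Compound 4 is therefore expected to give 5000 nM, within a range from 1800 nM to 14000 nM, which corresponds to an expected step of a 2.9-fold lower number from compound 1 to compound 4 (0.46 log units; beyond the scatter).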

Compound 4, half-maximal inhibitory concentration: 18600 nM
For compound 4 the middle estimate is 3.7-fold (0.57 log units) below the measured one; measured number above the stated range.
By their numbers in this assay, from the lowest: compounds 2 and 3 (each within the scatter of the next); then compounds 1 and 4 (each within the scatter of the next).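

In this assay, the change at this saturated chain carbon gives a 1.3-fold higher number from compound 1 to compound 4 (0.11 log units; within the scatter), so a shorter chain carrying ((4-chlorophenyl)sulfonyl)amino reads the same as the longer chain of compound 1 within the usual scatter. The step from compound 1 to compound 2 had changed the chain and the sulfonyl-to-carbonyl link together, leaving their contributions unseparated. With the chain held constant, the exchange on the amine nitrogen gives a 6.9-fold higher number from compound 2 to compound 4 (0.84 log units; beyond the scatter), showing that the shorter chain alone does not carry the lower number of compound 2.

As far as these compounds go, the step to compound 4 changes the chain and the ring halogen together, so a shift from one could be hidden by the other, and whether a methoxy group or an amine on that aromatic ring would lower the number remains open. Nothing presented here explains these differences.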